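This account rests on a few compounds, and the source may have more. Where it says the series, first, only, none or still open, it means among the compounds named here.

Measured so far in a functional assay on PC-3 cells (Homo sapiens) for antiproliferative activity, read by MTT assay, with a stated time of 72 h; a higher number here means a weaker inhibitor, a lower number a stronger inhibitor:
compound 1 `C/C(=N\NC(=O)c1cccc(S(=O)(=O)N2CCOCC2)c1)c1ccc(F)cc1`: 81300 nM
compound 2 `C/C(=N\NC(=O)c1cccc(S(=O)(=O)N2CCOCC2)c1)c1cccc(O)c1`: a limit only
compound 3 `C/C(=N\NC(=O)c1cccc(S(=O)(=O)N2CCOCC2)c1)c1ccc(O)cc1`: 36200 nM

Compound 2 reaches only the limit of this assay, > 100000 nM; the value the limit of > 100000 nM in this assay, at which 1 of the 3 values shown sits, is a limit and not a number. Among the two numbers shown, compound 3 sits lowest; its nearest neighbour is compound 1, and the step is a 2.2-fold lower number from compound 1 to compound 3 (0.35 log units; beyond the scatter). The step from compound 2 runs an at least 2.7-fold lower number from compound 2 to compound 3 (0.44 log units; beyond the scatter).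

Compound 4 `C/C(=N\NC(=O)c1cccc(S(=O)(=O)N2CCOCC2)c1)c1cc(O)ccc1O` differs from compound 3 in one place: 2,5-dihydroxyphenyl in place of 4-hydroxyphenyl on a carbon with a double bond to nitrogen. Within the data shown here, two measured steps bear on this. Exchange of fluoro for hydroxy gave a 2.2-fold lower number from compound 1 to compound 3 (0.35 log units; beyond the scatter), and moving the hydroxy from the 3-position to the 4-position of the phenyl gave an at least 2.7-fold lower number from compound 2 to compound 3 (0.44 log units; beyond the scatter). Among the measured compounds shown here, compound 4 keeps the 4-hydroxy arrangement that compound 3 has and adds a second hydroxy; no measured pair shows the effect of such an addition. The 3-hydroxy arrangement alone was weaker than the 4-hydroxy one, so a small drift toward higher numbers is possible, but within the scatter is the best expectation. For compound 4 in this assay a step of a 1.2-fold higher number from compound 3 to compound 4 (0.09 log units; within the scatter) is expected, and the estimated value is 45000 nM, with a range from 18000 nM to 110000 nM.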

Compound 4, half-maximal inhibitory concentration: > 100000 nM
Compound 4: only a limit was reported; the forecaster's own chance of this, stated with the estimate: 15%; middle value at least 2.2-fold (0.34 log units) away from the limit.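

In this assay compound 4 gives > 100000 nM, a limit and not a number. With 2,5-dihydroxyphenyl in place of 4-hydroxyphenyl the series shows an at least 2.7-fold higher number from compound 3 to compound 4 (0.44 log units; beyond the scatter), so a hydroxy on this phenyl does not by itself give the lower number, and among the hydroxy compounds only compound 3 reaches a number. Against the fluoro compound the result is an at least 1.2-fold higher number from compound 1 to compound 4 (0.08 log units; that floor lies within the scatter), a floor that supports no order between the two.

As far as these compounds go, the step between compound 2 and compound 4 cannot be read, and any order among the compounds at the ceiling stays hidden: the limit of > 100000 nM in this assay, at which 2 of the 4 values shown sit. Whether a methoxy or an amine on this phenyl would bring the number below that of compound 3 remains open.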